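Ortho-Hydroxyphenyl Chalcone Boronic Acid: Expected Cytotoxicity

A few compounds are considered here, and "the series" means these few. Any claim that something is new, unique, unknown or untested is made for them only; others in the source may bear on it.

Compound 1 `O=C(/C=C/c1ccc2c(c1)B(O)OC2)c1cccnc1` gives 18500 nM in a functional assay on SK-OV-3 cells (Homo sapiens) for cytotoxicity, read by MTT assay, with a stated time of 48 h; a lower number here means a stronger inhibitor, a higher number a weaker inhibitor. Compound 2 `O=C(/C=C/c1ccc2c(c1)B(O)OC2)c1ccc(O)cc1` gives 13000 nM. Compound 3 `O=C(/C=C/c1ccc2c(c1)B(O)OC2)c1cccc(F)c1` gives 4800 nM.

Compound 3 stands lowest of the three, with steps beyond the scatter to both others: a 3.9-fold lower number from compound 1 to compound 3 (0.59 log units; beyond the scatter) and a 2.7-fold lower number from compound 2 to compound 3 (0.43 log units; beyond the scatter). Compound 4 `O=C(/C=C/c1ccc2c(c1)B(O)OC2)c1ccccc1O` differs from compound 3 by 2-hydroxyphenyl in place of 3-fluorophenyl on a carbonyl carbon. Going by the values given here, the step bearing on it is the one from compound 2 to compound 3, a 2.7-fold lower number from compound 2 to compound 3 (0.43 log units; beyond the scatter), where a hydroxyphenyl was replaced by the fluorophenyl; compound 4 reverses that kind of change, with the hydroxyl in another ring position. A modest rise in the number is therefore expected for compound 4, roughly a 2.1-fold higher number from compound 3 to compound 4 (0.32 log units; beyond the scatter). Compound 4 is estimated at 10000 nM, within 4000 nM to 25000 nM.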

Compound 4, half-maximal inhibitory concentration: 48800 nM
Beside the measured number, compound 4's estimate is 4.9-fold (0.69 log units) below it; the measured number lies above the stated range.
By their numbers in this assay, from the lowest: compound 3; then compounds 2 and 1 (each within the scatter of the next); then compound 4.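

In this assay, the two hydroxyphenyl groups on the carbonyl carbon are not interchangeable: 2-hydroxyphenyl in place of 4-hydroxyphenyl gives a 3.8-fold higher number from compound 2 to compound 4 (0.57 log units; beyond the scatter), with only the place of the hydroxyl differing. Against 3-fluorophenyl the same group gives a 10-fold higher number from compound 3 to compound 4 (1.01 log units; beyond the scatter), the largest step in the set, and against pyridin-3-yl it gives a 2.6-fold higher number from compound 1 to compound 4 (0.42 log units; beyond the scatter), which makes compound 4 the weakest of the four. Nothing given here explains these differences. The compounds shown leave open how a 2-methoxyphenyl or 2-aminophenyl group on the carbonyl carbon would compare with 2-hydroxyphenyl, and where 3-hydroxyphenyl would fall.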